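The source may report more compounds than this note shows. Statements on the series, on what has been measured and on what is new or still open speak of the compounds shown alone.

Measured compounds:
Compound 1 `Cc1nc(C(F)(F)F)ccc1CNC(=O)C(C)c1ccc(NS(C)(=O)=O)c(F)c1`: 387 nM
Compound 2 `CC(C(=O)NCc1ccc(C(F)(F)F)nc1C1=CCCCC1)c1ccc(NS(C)(=O)=O)c(F)c1`: 0.7 nM
Compound 3 `CC(C(=O)NCc1ccc(C(F)(F)F)nc1C1=C[C@H](C)CCC1)c1ccc(NS(C)(=O)=O)c(F)c1`: 0.1 nM

In an assay on CHO cells for antagonist activity at transient receptor potential cation channel subfamily V member 1 (Homo sapiens), read by FLIPR and calcium flux (on this read-out lower numbers stand for stronger inhibition and higher numbers for weaker inhibition), compound 3 gives the lowest number of the three; compound 2 comes nearest, separated by a 7.0-fold lower number from compound 2 to compound 3 (0.85 log units; beyond the scatter), and compound 1 stands furthest away, separated by a 3900-fold lower number from compound 1 to compound 3 (3.59 log units; beyond the scatter). Compound 4 `CC(C)=Cc1nc(C(F)(F)F)ccc1CNC(=O)C(C)c1ccc(NS(C)(=O)=O)c(F)c1` has not been measured yet. Compared with compound 3 it carries 2-methylprop-1-en-1-yl in place of 3-methylcyclohex-1-en-1-yl on an aromatic carbon. Among the compounds with values here, two measured steps bear on this change. The step of a 550-fold lower number from compound 1 to compound 2 (2.74 log units; beyond the scatter) shows what the cyclohex-1-en-1-yl group brings relative to methyl on that aromatic carbon, and the step of a 7.0-fold lower number from compound 2 to compound 3 (0.85 log units; beyond the scatter) shows what the methyl on the saturated ring carbon adds on top. Compound 4 gives up the ring and the stereocentre but keeps a double bond outside aromatic rings on an open chain, which in heavy-atom count lies between the methyl of compound 1 and the rings of compounds 2 and 3. A step in this assay towards a higher number, smaller than the gap between compound 1 and compound 3 but beyond the scatter, is therefore expected from compound 3 to compound 4, estimated as a 100-fold higher number from compound 3 to compound 4 (2.00 log units; beyond the scatter). For compound 4 the estimate in this assay is 10 nM, between 1 nM and 100 nM.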

Compound 4, inhibition constant: 11.5 nM
Beside the measured number, compound 4's estimate is 1.2-fold (0.06 log units) below it, and the stated range covers the measured number.
By their numbers in this assay, from the lowest: compound 3; then compound 2; then compound 4; then compound 1.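

In this assay, the open-chain 2-methylprop-1-en-1-yl group on this aromatic carbon, next to the ring nitrogen, still improves clearly on methyl, with a 34-fold lower number from compound 1 to compound 4 (1.53 log units; beyond the scatter), so among the compounds shown a ring is not needed for a large part of the gain at this position. The ring-bearing groups nevertheless remain ahead of the open chain, as shown by a 16-fold higher number from compound 2 to compound 4 (1.22 log units; beyond the scatter) and, for the group with 7 heavy atoms replaced by the group with 4, by a 120-fold higher number from compound 3 to compound 4 (2.06 log units; beyond the scatter), so the chain recovers only part of what the two rings deliver. No measurement offered here accounts for the size of these steps.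

The compounds shown leave open what the double bond itself contributes: compounds 2, 3 and 4 all carry one at this position, and a saturated 2-methylpropyl chain or a cyclohexyl ring would separate its role from that of size and shape. They also leave open how an amine such as piperidin-1-yl, or the opposite configuration of the methyl-bearing ring carbon of compound 3, would fare here.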